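Swapping 4-methoxyphenyl for 2,4-dichlorophenyl on a shared core

The source may report more compounds than this note shows. Statements on the series, on what has been measured and on what is new or still open speak of the compounds shown alone.

Values measured in a functional assay on PC-3 cells (Homo sapiens) for cytotoxicity, read by MTT assay, with a stated time of 72 h; on this read-out higher numbers stand for weaker inhibition and lower numbers for stronger inhibition:
- Compound 1 `CNC(=O)c1cc(Oc2ccc(C(=O)/C=C/c3ccc(Br)cc3)cc2)ccn1`: 18500 nM
- Compound 2 `CNC(=O)c1cc(Oc2ccc(C(=O)/C=C/c3ccc(C#N)cc3)cc2)ccn1`: 3870 nM
- Compound 3 `CNC(=O)c1cc(Oc2ccc(C(=O)/C=C/c3ccc(OC)cc3)cc2)ccn1`: > 50000 nM (a limit of the assay, not a number)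

Compound 3 stands at the limit of > 50000 nM in this assay, at which 1 of the 3 values shown sits. Compound 4 `CNC(=O)c1cc(Oc2ccc(C(=O)/C=C/c3ccc(Cl)cc3Cl)cc2)ccn1` has 2,4-dichlorophenyl in place of 4-methoxyphenyl, on a double-bonded chain carbon bound to a double-bonded chain carbon: 2,4-dichlorophenyl in place of 4-methoxyphenyl on a double-bonded chain carbon bound to a double-bonded chain carbon.

Among the compounds with values here, two measured steps bear on this change, since both bring in the methoxy group that compound 4 lacks. Methoxy in place of bromo gave a modest or greater rise, an at least 2.7-fold higher number from compound 1 to compound 3 (0.43 log units; beyond the scatter). Methoxy in place of cyano gave a large rise, an at least 12-fold higher number from compound 2 to compound 3 (1.11 log units; beyond the scatter). Within the data shown here, no measured compound carries two chlorines, so the closest guide is the halogen-bearing compound 1 at 18500 nM. Leaving methoxy behind is therefore expected to move the number down in this assay, by a step of modest or larger size, an at least 4.1-fold lower number from compound 3 to compound 4 (0.61 log units; beyond the scatter). For compound 4 the estimate is 12000 nM, with an expected range from 3500 nM to 40000 nM.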

Compound 4, half-maximal inhibitory concentration: 9220 nM
Compound 4: middle estimate off by 1.3-fold (0.11 log units), on the high side, within the range that was stated.
By their numbers in this assay, from the lowest: compound 2; then compounds 4 and 1 (each within the scatter of the next). At a limit, above all of these: compound 3.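

In this assay, compound 3 is held at a limit of the assay, not a number: the limit of > 50000 nM in this assay, at which 1 of the 4 values shown sits.

At this place, on a double-bonded chain carbon bound to a double-bonded chain carbon, 2,4-dichlorophenyl brings a clear drop in the number, with an at least 5.4-fold lower number from compound 3 to compound 4 (0.73 log units; beyond the scatter), so a group with two chlorines also avoids the loss seen with 4-methoxyphenyl. The two halogen-bearing groups cannot be told apart, with a 2.0-fold lower number from compound 1 to compound 4 (0.30 log units; within the scatter), whereas 4-cyanophenyl keeps an edge, with a 2.4-fold higher number from compound 2 to compound 4 (0.38 log units; beyond the scatter).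

From the compounds shown here alone, whether this result needs both chlorines, or one alone would do, stays open. Also open, going by these compounds, is where a phenyl ring carrying an amine or a carboxylic acid would fall.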